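This account rests on a few compounds, and the source may have more. Where it says the series, first, only, none or still open, it means among the compounds named here.

Compound 1 `COc1cc(-c2nnc3n2NC(c2ccco2)C(C(=O)c2ccc(Cl)cc2)S3)cc(OC)c1OC` — > 100000 nM
Compound 2 `COc1cc(-c2nnc3n2NC(c2cccs2)C(C(=O)c2ccc(C)cc2)S3)cc(OC)c1OC` — 28400 nM

In a functional assay on MCF7 cells (Homo sapiens) for cytotoxicity, read by MTT assay, with a stated time of 48 h (a higher number here means a weaker inhibitor, a lower number a stronger inhibitor), compound 1 gives > 100000 nM, which is a limit of the assay rather than a number. Compound 2 gives 28400 nM, the only number shown. Compound 3 `COc1cc(-c2nnc3n2NC(c2cccs2)C(C(=O)c2ccccc2)S3)cc(OC)c1OC` differs from compound 2 by hydrogen in place of methyl on an aromatic carbon. Within the data shown here, no measured pair shows this change, so its size can only be expected: in this assay a shift no larger than the usual scatter, in either direction. The expected step is a 1.2-fold higher number from compound 2 to compound 3 (0.09 log units; within the scatter). Compound 3 is therefore estimated at 35000 nM, with a range from 12000 nM to 100000 nM.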

Compound 3, half-maximal inhibitory concentration: > 100000 nM
Compound 3: only a limit was reported (the forecaster's own chance of this, stated with the estimate: 25%); middle value at least 2.8-fold (0.45 log units) from the limit.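

With hydrogen in place of methyl, the step is an at least 3.5-fold higher number from compound 2 to compound 3 (0.54 log units; beyond the scatter), so this small change on the aromatic ring is not neutral in this assay. In this pair, the 4-methylphenyl group gives a measurable number, while the phenyl group does not. Compound 3 gives only a limit, so the true size of the step stays unknown: the limit of > 100000 nM in this assay, at which 2 of the 3 values shown sit.

Still open, on these data alone, is whether an amine or a longer chain such as propyl in place of the methyl would give a lower number than compound 2. Compound 1 differs from compound 2 in two places, so it cannot separate their effects.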